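The source may report more compounds than this note shows. Statements on the series, on what has been measured and on what is new or still open speak of the compounds shown alone.

Measured so far:
- compound 1 `CC(=O)Oc1ccccc1C(=O)O[C@H]1CO[C@H]2[C@@H]1OC[C@H]2OC(C)=O`: 0.0095 h
- compound 2 `CC(=O)Oc1ccccc1C(=O)O[C@H]1CO[C@H]2[C@@H]1OC[C@H]2OC(=O)c1ccccc1C`: 0.0138 h
- compound 3 `CC(=O)Oc1ccccc1C(=O)O[C@H]1CO[C@H]2[C@@H]1OC[C@H]2OC(=O)c1cccc(C)c1`: 0.0203 h

In an ADME assay on a cell-free system (plasma, Homo sapiens) for metabolic stability, with Plasma (Rattus norvegicus) as the target, read by HPLC, at pH 7.4 (a higher number here means that the compound lasts longer, a lower number that the compound disappears faster), compound 1 gives the lowest of the three numbers. Compound 4 `COc1ccc(C(=O)O[C@@H]2CO[C@H]3[C@@H]2OC[C@@H]3OC(=O)c2ccccc2OC(C)=O)cc1` is reached from compound 1 by one change: 4-methoxyphenyl in place of methyl on a carbonyl carbon.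

Going by the values given here, two steps bear on this, both replacing the same methyl on a carbonyl carbon with an aryl group: a 1.5-fold higher number from compound 1 to compound 2 (0.16 log units; within the scatter) and a 2.1-fold higher number from compound 1 to compound 3 (0.33 log units; beyond the scatter). Between the two aryl compounds, a 1.5-fold higher number from compound 2 to compound 3 (0.17 log units; within the scatter). A 4-methoxyphenyl in that position is expected to behave like these aryl replacements, so a small upward step in this assay is expected, a 2.0-fold higher number from compound 1 to compound 4 (0.30 log units; within the scatter), with no strong reason to expect more. Compound 4 is therefore estimated at 0.019 h, within 0.011 h to 0.034 h.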

Compound 4, half-life: 0.0183 h
Estimate against measurement, compound 4: 1.0-fold (0.02 log units) above; low and high end bracket the measured number.
By their numbers in this assay, from the lowest: compounds 1, 2, 4 and 3 (each within the scatter of the next, the first and the last beyond it).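

In this assay the change from acetyl to (4-methoxyphenyl)carbonyl gives a 1.9-fold higher number from compound 1 to compound 4 (0.28 log units; within the scatter) and so stays within the scatter, even with an added hydrogen-bond acceptor on the new aryl group. Among the aryl compounds, a 1.3-fold higher number from compound 2 to compound 4 (0.12 log units; within the scatter) and a 1.1-fold lower number from compound 3 to compound 4 (0.05 log units; within the scatter) leave 4-methoxyphenyl not separable from either methylphenyl group. Nothing available accounts for these half-lives.

Still open, as far as these compounds go, is whether an amine, a carboxylic acid or a longer alkyl chain in place of the methyl on this carbonyl carbon would shift the half-life beyond the scatter.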